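A few compounds are considered here, and "the series" means these few. Any claim that something is new, unique, unknown or untested is made for them only; others in the source may bear on it.

Four compounds share one core, differing in the aromatic ring attached to it and in the length of a short saturated chain. Compound 1, `CCc1nn(C)c2c1C(c1ccccc1F)=NCC(=O)N2`, carries a 2-fluorophenyl group; in a functional assay on the whole organism with Rattus norvegicus as the target (a lower number here means that less compound is needed, a higher number that more compound is needed for the effect), compound 1 gives 2 mg/kg; 2 mg/kg (2 entries). Compound 2, `CCc1nn(C)c2c1C(c1ccc(F)cc1)=NCC(=O)N2`, carries the fluorine at the other position of the ring, and in this assay compound 2 reaches only (the limit of > 500 mg/kg in this assay, at which 1 of the 3 values shown sits), reported as > 500 mg/kg rather than as a number. Compound 3, `CCc1nn(C)c2c1C(c1ccccc1Cl)=NCC(=O)N2`, carries a 2-chlorophenyl group and in this assay compound 3 gives 32 mg/kg. The change of ring gave an at least 15-fold lower number from compound 2 to compound 3 (1.19 log units; beyond the scatter). Among the measured compounds shown here, compound 3 thus holds the only single number in this assay beside that of compound 1, whose number is lower; compound 2 has only a limit.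

Compound 4, `CCCc1nn(C)c2c1C(c1ccccc1Cl)=NCC(=O)N2`, keeps the 2-chlorophenyl ring of compound 3 and differs only in the chain: methyl in place of hydrogen on a saturated chain carbon, two bonds along the chain from an aromatic carbon. For the measured compounds named here, no measured step touches this chain; the one step known concerns the aromatic ring and says nothing about lengthening ethyl to propyl. Compound 4 is therefore expected to show no change at the digits printed from compound 3 to compound 4 (within the scatter), a step not beyond the scatter. Compound 4 is estimated at 32 mg/kg, within 10 mg/kg to 100 mg/kg.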

Compound 4, minimum effective dose: 250 mg/kg
Compound 4: the middle estimate sits 7.8-fold (0.89 log units) below what was measured, and the stated range ends below it.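

The earlier compounds shown here varied only the aromatic ring, so they gave no information about the chain. In this assay, lengthening ethyl to propyl gives a 7.8-fold higher number from compound 3 to compound 4 (0.89 log units; beyond the scatter), which shows that this saturated chain position, two bonds along the chain from an aromatic carbon, also matters: adding just one methyl there means more compound is needed for the effect, even with the 2-chlorophenyl ring unchanged. Nothing in the data shown explains why this small change in the chain has an effect of this size.

The compounds shown leave open whether the same lengthening would have a similar effect with the 2-fluorophenyl ring of compound 1, since only the 2-chlorophenyl ring appears here with both chains. They also leave open how the number would move along a series of chains at this position, from a methyl group in place of the ethyl to a longer butyl chain, or with a chain ending in an amine or a carboxylic acid.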